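The source may hold more compounds than are shown below. What is called first, only, known or untested is meant among the compounds shown, and "the series" means these compounds.

Two compounds share one core and differ only in one group on an aromatic carbon. Compound 1, `Cc1ccc(-c2csc3nc(-c4cc(F)c(Cl)cc4Cl)nn23)cc1`, carries a methyl; in a functional assay on the whole organism (strain Wister albino) for inhibition, with Rattus norvegicus as the target, read by paw edema, with stated times of 30 min and 3 h, at a dose of 50 mg/kg by the oral route (on this read-out lower numbers stand for less inhibition and higher numbers for more inhibition at the one dose given (going by the name of the read-out)), compound 1 gives 0%. Compound 2, `Fc1ccc(-c2csc3nc(-c4cc(F)c(Cl)cc4Cl)nn23)cc1`, carries a fluoro instead, and in this assay compound 2 gives 48.8%. Going by the values given here, that single swap is the only measured step, a number 48.8 percentage points higher from compound 1 to compound 2 (beyond the scatter), so compound 2 stands highest of the two numbers, with compound 1 the nearest and lower by a margin beyond the scatter.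

Compound 3, `Fc1cc(-c2nc3scc(-c4ccc(Cl)cc4)n3n2)c(Cl)cc1Cl`, is not yet measured. It differs from compound 2 by chloro in place of fluoro on an aromatic carbon. Among the compounds with values here, the only step at hand, a number 48.8 percentage points higher from compound 1 to compound 2 (beyond the scatter), concerns a different group at this same spot: it shows that the group here can matter greatly, but not how a chloro compares with a fluoro. Within the data shown here, no measured pair gives a direct parallel. Without one, compound 3 is expected to shift by a number 10.8 percentage points lower from compound 2 to compound 3 (beyond the scatter), a small change that could fall either way. The estimate for compound 3 is 38%, with a range from 12% to 62%.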

Compound 3, a percentage reported as inhibition, in the whole organism at one dose (the size of the read-out at that dose, not a potency): 42.2%
The estimate for compound 3 lay 4.2 percentage points below the measured number; low and high end bracket the measured number.
By their numbers in this assay, from the lowest: compound 1; then compounds 3 and 2 (each within the scatter of the next).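

In this assay, the change from 4-fluorophenyl to 4-chlorophenyl gives a number 6.6 percentage points lower from compound 2 to compound 3 (within the scatter) and so, at this dose, the read-out does not separate chloro from fluoro on this aromatic carbon, para to a large group. Chloro in place of methyl gives a number 42.2 percentage points higher from compound 1 to compound 3 (beyond the scatter) and thus shows that the large gain over compound 1 is not unique to fluoro, since it appears with both groups tested against methyl. Nothing at hand explains why compound 1 stands apart from compound 2 and compound 3.

From the compounds shown here alone, whether bromo would match fluoro and chloro at this carbon remains open, and so does whether a methoxy group, an amine or a carboxylic acid would resemble methyl or these two groups. Readings at a single dose also leave open whether compound 2 and compound 3 would stay this close at other doses, and whether compound 1 would show any inhibition at a higher one.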